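Series notes: phenyl in place of trifluoromethyl

The source may hold more compounds than are shown below. What is called first, only, known or untested is meant among the compounds shown, and "the series" means these compounds.

Compound 1 `COc1cc2nc(N3CCN(C(=O)c4cccc5ccccc45)CC3)nc(N)c2cc1OC` and compound 2 `COc1cc2nc(N3CCN(S(=O)(=O)c4ccc(C(F)(F)F)cc4)CC3)nc(N)c2cc1OC` share one core and differ only in the group attached to it. In a functional assay on PC-3 cells (Homo sapiens) for inhibition (a higher number here means a weaker inhibitor, a lower number a stronger inhibitor), compound 1 gives 59000 nM and compound 2 gives 27000 nM, the lower of the two numbers; the gap between them lies beyond the usual scatter. Compound 3 `COc1cc2nc(N3CCN(S(=O)(=O)c4ccc(-c5ccccc5)cc4)CC3)nc(N)c2cc1OC` has not yet been measured. Relative to compound 2 it carries phenyl in place of trifluoromethyl on an aromatic carbon. Going by the values given here, nothing measured so far shows how this change plays out, so the step from compound 2 to compound 3 is expected to be a 1.1-fold lower number from compound 2 to compound 3 (0.03 log units; within the scatter), not beyond the scatter. Compound 3 is estimated at 25000 nM in this assay, with a range of 8000 nM to 80000 nM.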

Compound 3, half-maximal inhibitory concentration: 4200 nM
Estimate against measurement, compound 3: 6.0-fold (0.77 log units) above; the measured number lies below the stated range.
By their numbers in this assay, from the lowest: compound 3; then compound 2; then compound 1.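

Within this assay, replacing trifluoromethyl with phenyl on this aromatic carbon, para to a large group, gives a 6.4-fold lower number from compound 2 to compound 3 (0.81 log units; beyond the scatter) and moves compound 3 beyond the scatter. This position is therefore sensitive to the group it carries, and a second aromatic ring of carbon only is accepted there. This rests on a single pair, and no available data explain the change.

From the compounds shown here alone, whether an amine, a carboxylic acid or a longer chain at this carbon would keep the lower number remains open. Also open, going by these compounds, is whether a methoxy group on the added phenyl would keep it.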